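The compounds below may be only part of what the source reports. "The series", "measured", "known", "first", "only" and "open" are said of these compounds alone.

Of the compounds shown here, three built on one shared core have been tested in an assay on CHO cells for displacement of a labelled ligand from adenosine receptor A3 (Homo sapiens), read by scintillation counting, tested at 10 uM; on this read-out higher numbers stand for more inhibition at the one concentration tested (going by the name of the read-out) and lower numbers for less inhibition. Compound 1 `Cc1csc(N)c1C(=O)c1ccc(Cl)cc1` gives 1% in this assay. Compound 2 `Cc1c(-c2ccccc2)sc(N)c1C(=O)c1ccc(Cl)cc1` gives 1%; the step of no change at the digits printed from compound 1 to compound 2 (within the scatter) stays within the scatter. Compound 3 `CC(C)(C)Cc1c(-c2ccncc2)sc(N)c1C(=O)c1ccc(Cl)cc1` gives 6% in this assay, the highest of the three numbers as written, yet its gap to compound 1 and to compound 2 lies within the scatter, so the three numbers are level with one another.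

Compound 4 `Cc1ccccc1-c1sc(N)c(C(=O)c2ccc(Cl)cc2)c1CC(C)(C)C` has not been measured. It differs from compound 3 by 2-methylphenyl in place of pyridin-4-yl on an aromatic carbon. Among the compounds with values here, no measured step swaps one ring for another ring; the single step available, no change at the digits printed from compound 1 to compound 2 (within the scatter), shows no change. With all three numbers low and no step beyond the scatter, a small change, none beyond the scatter, is expected in this assay, and the expected step of a number 1 percentage points lower from compound 3 to compound 4 (within the scatter) is small. Compound 4 is therefore estimated at 5%, within 0% to 14%.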

Compound 4, a percentage reported as inhibition, at one concentration (the size of the read-out at that concentration, not a potency): 1%
Estimate against measurement, compound 4: 4 percentage points above; low and high end bracket the measured number.
By their numbers in this assay, from the lowest: compounds 1, 2, 4 and 3 (each within the scatter of the next).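

On the ring carbon next to the ring sulfur, with the neopentyl group kept in place, a ring of carbon only in place of a ring with one hetero atom gives a number 5 percentage points lower from compound 3 to compound 4 (within the scatter) in this assay. Within the data shown here, this is the first ring-for-ring swap, and it shows that 2-methylphenyl and pyridin-4-yl cannot be told apart at this position, since the ring nitrogen can go and a methyl group can come without a readable change. No measurement here bears on why the numbers stay so low.

From the compounds shown here alone, whether any group at this carbon can lift the number clearly above the scatter remains open. A carboxylic acid or a longer chain ending in an amine, set in place of the ring, would test that question.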